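Swapping Ethyl for tert-Butyl on the Sulfonamide Ring

This account rests on a few compounds, and the source may have more. Where it says the series, first, only, none or still open, it means among the compounds named here.

Three measured compounds share one core and differ only in the group carried on the sulfonamide nitrogen. Compound 1 `CCc1ccc(NS(=O)(=O)c2ccc(N3CCNC3=O)cc2)cc1` bears a 4-ethylphenyl there, and in a functional assay on HT-29 cells (Homo sapiens) for antiproliferative activity, read by sulforhodamine B assay, with a stated time of 48 h (on this read-out lower numbers stand for stronger inhibition and higher numbers for weaker inhibition), compound 1 gives 660 nM. Compound 2 `O=C1NCCN1c1ccc(S(=O)(=O)Nc2ccc(F)c(F)c2)cc1` gives 350 nM, and compound 3 `COc1cccc(NS(=O)(=O)c2ccc(N3CCNC3=O)cc2)c1` gives 120 nM. Compound 1 thus sits at the upper end of the three numbers: the step of a 1.9-fold lower number from compound 1 to compound 2 (0.28 log units; within the scatter) stays within the scatter, while the steps of a 5.5-fold lower number from compound 1 to compound 3 (0.74 log units; beyond the scatter) and a 2.9-fold lower number from compound 2 to compound 3 (0.46 log units; beyond the scatter) are modest but real.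

Compound 4 `CC(C)(C)c1ccc(NS(=O)(=O)c2ccc(N3CCNC3=O)cc2)cc1` differs from compound 1 by tert-butyl in place of ethyl on an aromatic carbon. Going by the values given here, no measured step isolates this kind of change; each of the steps above exchanges the entire aryl group on the sulfonamide nitrogen rather than altering a single substituent on it. They show only that this part of the molecule can shift the number to a modest degree. Among the compounds with values here, with no direct precedent for enlarging ethyl to tert-butyl, the change is expected to leave the number close to where compound 1 stands, and the expected step is a 1.2-fold higher number from compound 1 to compound 4 (0.08 log units; within the scatter). Compound 4 is therefore estimated at 800 nM, within a range from 300 nM to 2200 nM.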

Compound 4, half-maximal inhibitory concentration: > 1000 nM
Compound 4 ended at the assay's limit; the forecaster's own chance of this, stated with the estimate: 5%; middle value at least 1.2-fold (0.09 log units) away from the limit.
By their numbers in this assay, from the lowest: compound 3; then compounds 2 and 1 (each within the scatter of the next). At a limit, above all of these: compound 4.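

In this assay, compound 4 reads as a limit and not as a number: the limit of > 1000 nM in this assay, at which 1 of the 4 values shown sits. Even so, this is the first step shown that alters a single substituent on the aryl group rather than exchanging the whole group, and tert-butyl in place of ethyl gives an at least 1.5-fold higher number from compound 1 to compound 4 (0.18 log units; that floor lies within the scatter). The step is a floor, so the true change may be larger, but it cannot be said to lie beyond the scatter; what the pair does show is that going from 2 heavy atoms to 4 on this aromatic carbon, para to a large group, brought no gain in inhibition of cell growth, and the number for compound 4 stands at a limit above the numbers of all three other compounds.

The true number of compound 4 stays unknown, and so does the shape of the trend at this position, since only ethyl and tert-butyl are shown there. As far as these compounds go, how the number would respond to isopropyl, to an amine or to a carboxylic acid on the same carbon remains open.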